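The source may hold more compounds than are shown below. What is called first, only, known or untested is meant among the compounds shown, and "the series" means these compounds.

Series notes. In a functional assay on the whole organism (artery, strain albino) with Rattus norvegicus as the target, with a stated time of 300 min, at a dose of 10 mg/kg by the oral route (on this read-out higher numbers stand for more inhibition at the one dose given (going by the name of the read-out) and lower numbers for less inhibition), compound 1 `CC1=C(C(=O)Nc2ccc(F)cc2)C(c2ccc([N+](=O)[O-])cc2)N=C(SCc2cccc(Cl)c2)N1` gives 18.5%. Compound 2 `CC1=C(C(=O)Nc2ccc(F)cc2)C(c2ccc([N+](=O)[O-])cc2)N=C(SCc2ccc(Cl)cc2)N1` carries the change (4-chlorophenyl in place of 3-chlorophenyl on a saturated chain carbon bound to a sulfur); in this assay compound 2 gives 37.9%, and the measured step is a number 19.4 percentage points higher from compound 1 to compound 2 (beyond the scatter). Compound 3 `CC1=C(C(=O)Nc2ccc([N+](=O)[O-])cc2)C(c2cccc([N+](=O)[O-])c2)N=C(SCc2cccc(Cl)c2)N1` rests on a different core; how the two cores differ is not broken down here. In this assay compound 3 gives 21%, which lies near the value of compound 1 and well under that of compound 2. Compound 4 `CC1=C(C(=O)Nc2ccc([N+](=O)[O-])cc2)C(c2cccc([N+](=O)[O-])c2)N=C(SCc2ccc(Cl)cc2)N1` is not yet measured; it relates to compound 3 by 4-chlorophenyl in place of 3-chlorophenyl on a saturated chain carbon bound to a sulfur, the same change at the same place as between compound 1 and compound 2. Within the data shown here, only one earlier instance of this change exists, so the expected step is taken somewhat smaller: a number 15 percentage points higher from compound 3 to compound 4 (beyond the scatter), resting on a number 19.4 percentage points higher from compound 1 to compound 2 (beyond the scatter). For compound 4 the estimate in this assay is 36%, between 22% and 52%.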

Compound 4, a percentage reported as inhibition, in the whole organism at one dose (the size of the read-out at that dose, not a potency): 24.1%
For compound 4 the middle estimate is 11.9 percentage points above the measured one; measured number inside the range.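

In this assay, the step of a number 3.1 percentage points higher from compound 3 to compound 4 (within the scatter) does not match the earlier result for 4-chlorophenyl in place of 3-chlorophenyl: the same change on two cores in this assay, a number 19.4 percentage points higher (beyond the scatter) from compound 1 to compound 2 and a number 3.1 percentage points higher (within the scatter) from compound 3 to compound 4, 16.3 percentage points apart, beyond the scatter of two such steps

The size of this change therefore did not carry from one core to the other, and a step measured on one core is a poor guide to the step on the other. This does not show which difference between the cores matters, and one pair per core gives no rule for any further core.

Open, as far as these compounds go, is whether the aryl group on the amide or the nitrophenyl group governs the size of the step. Also open, from the compounds shown here alone, is what an unsubstituted benzyl or a longer alkyl chain on the sulfur would give.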